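A few compounds are considered here, and "the series" means these few. Any claim that something is new, unique, unknown or untested is made for them only; others in the source may bear on it.

In a functional assay on A549 cells (Homo sapiens) for antiproliferative activity, read by MTT assay, with a stated time of 48 h (on this read-out lower numbers stand for stronger inhibition and higher numbers for weaker inhibition), compound 3 (`COc1ccc(/C=C/c2cc(OC)cc(OC)c2/C=C/C(=O)c2cccc(Cl)c2)cc1`) gives 5.6 ug/mL and sits within the scatter of both other measured compounds. Compound 1 (`CCCCCCCCCCCCOc1ccc(C(=O)/C=C/c2c(/C=C/c3ccc(OC)cc3)cc(OC)cc2OC)cc1`) gives 7.9 ug/mL and compound 2 (`COc1ccc(/C=C/c2cc(OC)cc(OC)c2/C=C/C(=O)c2cccc(Br)c2)cc1`) gives 8.1 ug/mL on the same read-out, so these three numbers cannot be put in a firm order.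

Compound 4 (`COc1ccc(/C=C/c2cc(OC)cc(OC)c2/C=C/C(=O)c2ccc(Cl)cc2)cc1`) has not been measured yet. It holds the same atoms as compound 3, joined differently, and 4-chlorophenyl in place of 3-chlorophenyl on a carbonyl carbon is the whole change: 4-chlorophenyl in place of 3-chlorophenyl on a carbonyl carbon.

One measured step comes close, namely a 1.4-fold lower number from compound 2 to compound 3 (0.16 log units; within the scatter) when chloro takes the place of bromo on an aromatic carbon. That step lies within the scatter, but it is a different kind of change. Among the measured compounds shown here, no measured pair compares 3-chlorophenyl with 4-chlorophenyl, so the data give only a weak guide. The expectation therefore starts from compound 3 at 5.6 ug/mL and from the small size of that single step, and no shift in either direction beyond the scatter is expected in this assay. The estimated change is a 1.1-fold higher number from compound 3 to compound 4 (0.03 log units; within the scatter) and would be too small to read as real. For compound 4 the expected value is 6 ug/mL with an estimated range from 3 ug/mL to 12 ug/mL on this read-out.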

Compound 4, half-maximal inhibitory concentration: 6.4 ug/mL
Estimate against measurement, compound 4: 1.1-fold (0.03 log units) below, within the range that was stated.
By their numbers in this assay, from the lowest: compounds 3, 4, 1 and 2 (each within the scatter of the next).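

In this assay, among the compounds shown here, 4-chlorophenyl in place of 3-chlorophenyl on the carbonyl carbon gives a 1.1-fold higher number from compound 3 to compound 4 (0.06 log units; within the scatter) and is the first direct comparison of these two groups, so no difference between them can be read at this place on the shared core. Putting 4-chlorophenyl in place of 3-bromophenyl, which changes both the halogen and its numbered ring position, gives a 1.3-fold lower number from compound 2 to compound 4 (0.10 log units; within the scatter) and also leaves no readable difference, so none of the steps among compound 2, compound 3 and compound 4 separates these three compounds. No measurement of any other property accompanies these numbers, so the data offer no explanation for this result.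

Going by these compounds, it remains open whether a group of a different kind on this phenyl ring, such as an amine or a carboxylic acid in place of the halogen, would move the number beyond the scatter. On these data alone, it is also open whether these halogen changes would stay as small in any test other than this assay.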